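Swapping the benzyl substituent on a piperidine-bearing inhibitor

The compounds below may be only part of what the source reports. "The series", "measured", "known", "first", "only" and "open" are said of these compounds alone.

This study concerns a small family of compounds that share one core and differ only in the group attached to the amine nitrogen of a saturated ring. Compound 1 `O=c1c2cnn(-c3ccc(F)cc3)c2ncn1CC1(O)CCN(Cc2ccccn2)CC1` and compound 2 `O=c1c2cnn(-c3ccc(F)cc3)c2ncn1CC1(O)CCN(Cc2ccc(F)cc2)CC1` belong to the family, but neither offers a number to compare: in an assay on Sf21 cells for inhibition of ubiquitin carboxyl-terminal hydrolase 7 (Homo sapiens), read by spectrophotometry, with stated times of 30 min and 2 h (a lower number here means a stronger inhibitor, a higher number a weaker inhibitor), compound 1 is given as "not determined" (no result reported), and compound 2 is given as "not determined" (no result reported). Compound 3 `COC(=O)c1ccc(CN2CCC(O)(Cn3cnc4c(cnn4-c4ccc(F)cc4)c3=O)CC2)c(Br)c1` is therefore the single anchor: in this assay compound 3 gives 900 nM, and with no other number in view it cannot be ranked against anything.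

Compound 4 `N#Cc1cc(Cl)ccc1CN1CCC(O)(Cn2cnc3c(cnn3-c3ccc(F)cc3)c2=O)CC1` is the next design, still unmeasured. It differs from compound 3 in one place: 4-chloro-2-cyanophenyl in place of 2-bromo-4-(methoxycarbonyl)phenyl on a saturated chain carbon bound to an amine nitrogen in a ring. For the measured compounds named here, no measured pair with a comparable change exists here, so nothing shows which way such a swap moves this assay.

Lacking such guidance, the expectation is a step from compound 3 to compound 4 of a 1.1-fold higher number from compound 3 to compound 4 (0.05 log units; within the scatter), which is no larger than the ordinary scatter of repeat measurements. Compound 4 is therefore estimated at 1000 nM in this assay, with a plausible range from 300 nM to 3500 nM, anchored only because compound 3 sits at 900 nM.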

Compound 4, half-maximal inhibitory concentration: 11400 nM
The estimate for compound 4 lay 11-fold (1.06 log units) below the measured number; measured number outside the range, above it.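

The group on the saturated chain carbon bound to the ring amine nitrogen clearly matters: in this assay, replacing 2-bromo-4-(methoxycarbonyl)phenyl with 4-chloro-2-cyanophenyl gives a 13-fold higher number from compound 3 to compound 4 (1.10 log units; beyond the scatter) and so leaves compound 3 the stronger inhibitor of this pair. For the compounds shown here, this is the first sign that the number responds to a change at this position, but the swap alters several things at once: the bromine and the methoxycarbonyl group leave, while the chlorine and the nitrile enter, so this one step cannot assign the loss to any single group. No measurement shown here accounts for the size or direction of the step.

As far as these compounds go, it remains open whether the bromine or the methoxycarbonyl group contributes more to the stronger result for compound 3, and whether the chlorine or the nitrile contributes more to the weaker result for compound 4. The compounds shown also leave unanswered how an unsubstituted benzyl group, or a benzyl group carrying a carboxylic acid or an amine, would compare.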